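The source may report more compounds than this note shows. Statements on the series, on what has been measured and on what is new or still open speak of the compounds shown alone.

Working notes on the series in a functional assay on SK-BR-3 cells (Homo sapiens) for antiproliferative activity, read by MTT assay, with a stated time of 72 h (on this read-out lower numbers stand for stronger inhibition and higher numbers for weaker inhibition), follow; no measured compound here gives a number. Compound 1 `C=C(C)CCOC(=O)C[C@@H]1C(C(=O)OC)=CO[C@@H](O[C@@H]2O[C@H](COC(C)=O)[C@@H](OC(C)=O)[C@H](OC(C)=O)[C@H]2OC(C)=O)/C1=C/C` reads > 15000 nM as a limit of the assay. Compound 2 `C/C=C1/[C@H](O[C@@H]2O[C@H](COC(C)=O)[C@@H](OC(C)=O)[C@H](OC(C)=O)[C@H]2OC(C)=O)OC=C(C(=O)OC)[C@H]1CC(=O)O` reads > 15000 nM as a limit of the assay. Compound 3 `C/C=C1/[C@H](O[C@@H]2O[C@H](COC(C)=O)[C@@H](OC(C)=O)[C@H](OC(C)=O)[C@H]2OC(C)=O)OC=C(C(=O)OC)[C@H]1CC(=O)SCCC` reads > 15000 nM as a limit of the assay. Compound 3 therefore stands with the others at the limit of > 15000 nM in this assay, at which 3 of the 3 values shown sit, and has no rank of its own.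

Compound 4 `C=CCOC(=O)C[C@@H]1C(C(=O)OC)=CO[C@@H](O[C@@H]2O[C@H](COC(C)=O)[C@@H](OC(C)=O)[C@H](OC(C)=O)[C@H]2OC(C)=O)/C1=C/C` carries allyloxy in place of propylsulfanyl on a carbonyl carbon is the whole difference. The same place changes in a step that the two limits leave unreadable from compound 1 to compound 3 and in a step that the two limits leave unreadable from compound 2 to compound 3 and also in a step that the two limits leave unreadable from compound 1 to compound 2 so no step size can be carried over. With no readable step behind it, no shift beyond the scatter is expected in this assay and a further limit is the likely report. The estimated step is a step that the limit leaves unreadable from compound 3 to compound 4 as an expectation only. The estimate for compound 4 is 20000 nM with an expected range from 15000 nM to 40000 nM in this read-out.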

Compound 4, half-maximal inhibitory concentration: > 20000 nM
Compound 4: only a limit was reported; the forecaster's own chance of this, stated with the estimate: 90%; the middle value sits exactly at the limit.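

In this assay compound 4 gives > 20000 nM, a limit of the assay, so the steps to it from compound 1, compound 2 and compound 3 cannot be read. The compounds shown leave open whether any group on this carbonyl carbon gives a measurable value.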